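A few compounds are considered here, and "the series" means these few. Any claim that something is new, unique, unknown or untested is made for them only; others in the source may bear on it.

Working notes on the series. Compound 2 `CCNC(=O)/C=C1\CCc2ccc(F)cc21` is the reference for the next step. For the measured compounds named here, in a functional assay on the whole organism with Rattus norvegicus as the target, at a dose of 20 mg/kg by the oral route (a lower number here means less inhibition, a higher number more inhibition at the dose given (going by the name of the read-out)), compound 2 gives 45%, the highest of the three numbers so far, though the gap to compound 3 lies within the scatter and only the gap to compound 1 lies beyond it. Compound 3 `CNC(=O)/C=C1\CCc2cc(Cl)ccc21` gives 40% in this assay, and compound 1 `O=C(/C=C1\CCc2cc(Cl)ccc21)NC1CC1` gives 34%.

Going by the values given here, the one measured single step in the set, methyl in place of cyclopropyl on an amide-type nitrogen, reads a number 6 percentage points higher from compound 1 to compound 3 (within the scatter), within the scatter. Compound 2 and compound 3 differ in two places at once, so their two values can only be set side by side; they are within the scatter of each other.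

Compound 4 `CCCNC(=O)/C=C1\CCc2ccc(F)cc21` is not yet measured. It differs from compound 2 by methyl in place of hydrogen on a saturated chain carbon, two bonds along the chain from an amide-type nitrogen. Among the compounds with values here, no measured step changes the chain on the amide nitrogen in just this way; the one step that alters the amide substituent at all stayed within the scatter, which gives no ground to expect a shift beyond it in this assay.

The estimate for compound 4 in this assay is therefore 45%, with a range from 30% to 60%, a step of no change at the digits printed from compound 2 to compound 4 (within the scatter) expected.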

Compound 4, a percentage reported as inhibition, in the whole organism at one dose (the size of the read-out at that dose, not a potency): 0%
Beside the measured number, compound 4's estimate is 45 percentage points above it; the measured number lies below the stated range.
By their numbers in this assay, from the lowest: compound 4; then compounds 1, 3 and 2 (each within the scatter of the next, the first and the last beyond it).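

In this assay, the change from ethylamino to propylamino, methyl in place of hydrogen on a saturated chain carbon, two bonds along the chain from an amide-type nitrogen, reads a number 45 percentage points lower from compound 2 to compound 4 (beyond the scatter) and leaves compound 4 at 0%. The only earlier change to the amide substituent, a number 6 percentage points higher from compound 1 to compound 3 (within the scatter), gave no sign of this, so the substituent on the amide nitrogen is now shown to be a place where a single added methyl can remove the whole read-out at this dose, at least in the pair compound 2 and compound 4. Nothing available bears on why the read-out falls so far at this step.

The compounds shown leave open whether the loss is tied to the propyl chain alone or continues with a longer chain such as butyl, and whether a branched isopropyl group or a cyclopropyl group on the core of compound 2 would behave like ethyl or like propyl. They also leave open whether a propyl chain ending in a hydroxyl group or an amine would restore the read-out, and whether the same step holds on the core of compound 3.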